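Adding a Methyl on the Bridge Carbon of Compound 2

The source may report more compounds than this note shows. Statements on the series, on what has been measured and on what is new or still open speak of the compounds shown alone.

Two compounds of this series share one core and differ in one place. Compound 1 `O=c1cc(Cc2c(F)cccc2F)nc(N2CCCCCC2)[nH]1` carries a hydrogen where compound 2 `Cc1c(Cc2c(F)cccc2F)nc(N2CCCCCC2)[nH]c1=O` carries a methyl on an aromatic carbon. In an ADME assay on MT4 cells (Homo sapiens) for cytotoxicity, read by MTT assay, with a stated time of 4 days (on this read-out higher numbers stand for lower toxicity in this test and lower numbers for higher toxicity in this test), compound 1 gives > 78000 nM, which is a limit of the assay rather than a number. In this assay compound 2 gives > 75000 nM, likewise a limit. The step that the two limits leave unreadable from compound 1 to compound 2 therefore cannot be read, because the limit of > 75000 nM in this assay, at which 1 of the 2 values shown sits, and the limit of > 78000 nM in this assay, at which 1 of the 2 values shown sits, each hold one of the two values.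

Compound 3 `Cc1c(C(C)c2c(F)cccc2F)nc(N2CCCCCC2)[nH]c1=O` departs from compound 2 by one change: methyl in place of hydrogen on a saturated chain carbon bound to two aromatic carbons. Going by the values given here, no measured step bears on this change, and the one step available is unreadable. For compound 3 a limit again seems the most likely outcome, so the estimated step is a step that the limit leaves unreadable from compound 2 to compound 3. Compound 3 is thus expected to give about 80000 nM, with a range from 40000 nM to 200000 nM.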

Compound 3, half-maximal cytotoxic concentration: > 72000 nM
Compound 3: a limit, no number; the forecaster's own chance of this, stated with the estimate: 75%; the middle value does not contradict the limit.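

In this assay, compound 2 and compound 3 each give a limit and not a number, and the step between them cannot be read. The compounds shown leave open at what concentration any of them would harm these cells, and whether either added methyl changes that.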